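The source may report more compounds than this note shows. Statements on the series, on what has been measured and on what is new or still open speak of the compounds shown alone.

Compound 1 `Cc1ccc(NC(=S)NC(=O)c2ccc(OCc3ccccc3F)cc2)cc1-c1nc2ccccc2[nH]1`: 1870 nM
Compound 2 `Cc1ccc(NC(=O)NC(=O)c2ccc(OCc3ccccc3)cc2)cc1-c1nc2ccccc2[nH]1`: 16400 nM
Compound 3 `Cc1ccc(NC(=O)NC(=O)c2ccc(OCc3cccc(C(F)(F)F)c3)cc2)cc1-c1nc2ccccc2[nH]1`: 3520 nM

In a functional assay on HT-29 cells (Homo sapiens) for inhibition, read by MTT assay, with a stated time of 48 h (on this read-out higher numbers stand for weaker inhibition and lower numbers for stronger inhibition), compound 3 gives 3520 nM, the second highest number of the three; compound 1 lies within the scatter of it, while compound 2 sits beyond the scatter at a higher number. Compound 4 `Cc1ccc(COc2ccc(C(=O)NC(=O)Nc3ccc(C)c(-c4nc5ccccc5[nH]4)c3)cc2)cc1` differs from compound 3 by 4-methylphenyl in place of 3-(trifluoromethyl)phenyl on a saturated chain carbon bound to an oxygen on an aromatic ring. Within the data shown here, the only measured step touching this part of the molecule is a 4.7-fold lower number from compound 2 to compound 3 (0.67 log units; beyond the scatter), where trifluoromethyl entered in place of hydrogen. Among the measured compounds shown here, compound 4 gives up that trifluoromethyl and carries a methyl instead, and no measured pair shows a methyl at this place. A number between compound 2 and compound 3 is therefore expected, with wide uncertainty. Compound 4 is estimated at 6500 nM (range 2500 nM to 16000 nM), an expected step of a 1.8-fold higher number from compound 3 to compound 4 (0.27 log units; within the scatter).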

Compound 4, half-maximal inhibitory concentration: 5110 nM
Compound 4: the middle estimate sits 1.3-fold (0.10 log units) above what was measured, and the stated range covers the measured number.
By their numbers in this assay, from the lowest: compounds 1, 3 and 4 (each within the scatter of the next, the first and the last beyond it); then compound 2.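

In this assay, the exchange of 3-(trifluoromethyl)phenyl for 4-methylphenyl gives a 1.5-fold higher number from compound 3 to compound 4 (0.16 log units; within the scatter), so trifluoromethyl is not the only substituent on this ring compatible with a number in this range. Methyl also separates from the unsubstituted ring, with a 3.2-fold lower number from compound 2 to compound 4 (0.51 log units; beyond the scatter), which leaves compound 2 apart from both substituted compounds 3 and 4. Nothing available explains either step.

Going by these compounds, whether a methoxy group or a carboxylic acid on this ring would fit the same picture remains open. The effects of group and ring location also remain unseparated, since 3-(trifluoromethyl)phenyl and 4-methylphenyl differ in both.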